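From 4-methoxyphenyl to thiophen-2-yl: estimating growth inhibition

The compounds below may be only part of what the source reports. "The series", "measured", "known", "first", "only" and "open" are said of these compounds alone.

- compound 1 (`COc1cc(/C=C/C(=O)/C=C/c2cccc3ccccc23)ccc1OCc1cn(CCCOc2cc(=O)oc3ccccc23)nn1`) shows 71% inhibition
- compound 2 (`COc1ccc(/C=C/C(=O)/C=C/c2ccc(OCc3cn(CCCOc4cc(=O)oc5ccccc45)nn3)c(OC)c2)cc1`) shows 56% inhibition

In a functional assay on THP-1 cells (Homo sapiens) for inhibition, read by sulforhodamine B assay, with a stated time of 48 h, tested at 50 uM (a higher number here means more inhibition of growth at the concentration tested, a lower number less inhibition of growth), compound 2 holds the lower of the two numbers, at 56% inhibition. Compound 3 (`COc1cc(/C=C/C(=O)/C=C/c2cccs2)ccc1OCc1cn(CCCOc2cc(=O)oc3ccccc23)nn1`) differs from it in one place (thiophen-2-yl in place of 4-methoxyphenyl on a double-bonded chain carbon bound to a double-bonded chain carbon) and has not yet been measured. For the measured compounds named here, only one measured step bears on this place: a number 15 percentage points lower from compound 1 to compound 2 (beyond the scatter) when one group there was exchanged for another. Going by the values given here, no measured compound carries thiophen-2-yl, so a step of similar or smaller size is expected, leaning slightly upward. The estimated change is a number 6 percentage points higher from compound 2 to compound 3 (within the scatter) in this reading. Compound 3 is expected to give 62% in this assay with a likely range from 47% to 77% around that estimate.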

Compound 3, percent growth inhibition at one concentration: 54%
For compound 3 the middle estimate is 8 percentage points above the measured one; low and high end bracket the measured number.
By their numbers in this assay, from the lowest: compounds 3 and 2 (each within the scatter of the next); then compound 1.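

In this assay, exchanging 4-methoxyphenyl for the five-membered thiophen-2-yl ring, which has fewer heavy atoms, gives a number 2 percentage points lower from compound 2 to compound 3 (within the scatter) and so separates the two groups by nothing firm. Thiophen-2-yl in place of naphthalen-1-yl gives a number 17 percentage points lower from compound 1 to compound 3 (beyond the scatter) and shows that, of these three groups, naphthalen-1-yl alone stands apart at this place. No measurement offered here explains this pattern.

Open, as far as these compounds go, is whether another fused ring system, such as quinolin-4-yl, would stand with naphthalen-1-yl, and how a phenyl ring bearing an amine or a carboxylic acid would compare.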